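This account rests on a few compounds, and the source may have more. Where it says the series, first, only, none or still open, it means among the compounds named here.

Measured in an ADME assay on microsomes from liver (Homo sapiens) for metabolic stability, read by LC-MS, tested at 1 mM; on this read-out lower numbers stand for a shorter-lived compound and higher numbers for a longer-lived compound:
compound 1 `N#Cc1ccc(F)cc1Cn1c(N2CCC[C@@H](N)C2)nc2c(-c3ccc(F)cc3)c[nH]c2c1=O`: 3.01 h
compound 2 `N#Cc1ccc(F)cc1Cn1c(N2CCC[C@@H](N)C2)nc2c(F)c[nH]c2c1=O`: 1.64 h
compound 3 `CC(C)S(=O)(=O)c1ccc(-c2c[nH]c3c(=O)n(Cc4cc(F)ccc4C#N)c(N4CCC[C@@H](N)C4)nc23)cc1`: 0.722 h

Compound 3, at 0.722 h, has the lowest number of the three in this assay. Both of its steps lie beyond the scatter: a 2.3-fold lower number from compound 2 to compound 3 (0.36 log units; beyond the scatter) and a 4.2-fold lower number from compound 1 to compound 3 (0.62 log units; beyond the scatter). The remaining step, a 1.8-fold lower number from compound 1 to compound 2 (0.26 log units; within the scatter), stays within the scatter.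

Compound 4 `CS(=O)(=O)c1ccc(-c2c[nH]c3c(=O)n(Cc4cc(F)ccc4C#N)c(N4CCC[C@@H](N)C4)nc23)c(F)c1` has not yet been measured. It differs from compound 3 as follows: 2-fluoro-4-(methylsulfonyl)phenyl in place of 4-(isopropylsulfonyl)phenyl on an aromatic carbon. In words, 2-fluoro-4-(methylsulfonyl)phenyl stands in place of 4-(isopropylsulfonyl)phenyl, on an aromatic carbon of the five-membered aromatic ring with 1 nitrogen.

Among the measured compounds shown here, no measured step exchanges one sulfonyl group for another, and none adds fluoro to this phenyl, so the evidence is indirect. The closest guides are the two modest steps that introduced the leaving group, a 2.3-fold lower number from compound 2 to compound 3 (0.36 log units; beyond the scatter) and a 4.2-fold lower number from compound 1 to compound 3 (0.62 log units; beyond the scatter). Compound 4 still carries a sulfonyl-bearing phenyl, so it is expected to stay close to compound 3 at 0.722 h, not to return to the level of compound 1 at 3.01 h. The expected change is small and upward, within the scatter: a 1.4-fold higher number from compound 3 to compound 4 (0.14 log units; within the scatter). The estimate for compound 4 is 1 h, with an expected range of 0.5 h to 2 h.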

Compound 4, half-life: > 3.33 h
Compound 4: only a limit was reported (the forecaster's own chance of this, stated with the estimate: 3%); middle value at least 3.3-fold (0.52 log units) from the limit.
By their numbers in this assay, from the lowest: compound 3; then compounds 2 and 1 (each within the scatter of the next). At a limit, above all of these: compound 4.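

In this assay, compound 4 is reported only as a limit, not as a number: the limit of > 3.33 h in this assay, at which 1 of the 4 values shown sits.

The earlier compounds shown here had linked a sulfonyl-bearing phenyl at this position, on an aromatic carbon of the five-membered aromatic ring with 1 nitrogen, with the lowest number, but this result shows that such a phenyl does not by itself hold the half-life there, since exchanging 4-(isopropylsulfonyl)phenyl for 2-fluoro-4-(methylsulfonyl)phenyl gives an at least 4.6-fold higher number from compound 3 to compound 4 (0.66 log units; beyond the scatter). The other two comparisons are floors only, an at least 2.0-fold higher number from compound 2 to compound 4 (0.30 log units; that floor lies within the scatter) and an at least 1.1-fold higher number from compound 1 to compound 4 (0.04 log units; that floor lies within the scatter), and neither floor by itself establishes a gap beyond the scatter, so the size of these differences stays undetermined.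

The change removes the isopropyl group in favour of methyl and adds fluoro to the phenyl in a single step, so the compounds shown cannot say which of the two edits carries the rise. Going by these compounds, a 4-(methylsulfonyl)phenyl group without the fluoro, or a 2-fluoro-4-(isopropylsulfonyl)phenyl group, would separate them, and how a sulfonamide or a carboxylic acid on this phenyl would behave remains open.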